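Cytotoxicity limits across three compounds and one analogue

This account rests on a few compounds, and the source may have more. Where it says the series, first, only, none or still open, it means among the compounds named here.

The readout throughout is an ADME assay on BaF3 cells (Mus musculus) for cytotoxicity; a lower number here means that less compound is needed, a higher number that more compound is needed for the effect. Three measured compounds carry the same trifluoromethoxy-substituted anilino group on differing cores. Compound 1 is `NS(=O)(=O)c1ccc(-c2cc(Nc3ccc(OC(F)(F)F)cc3)ncn2)cc1`; in this assay compound 1 reaches only the limit of > 10000 nM. Compound 2 is `CCn1ncc2c(Nc3ccc(OC(F)(F)F)cc3)ncnc21`; in this assay compound 2 likewise reaches only the limit of > 10000 nM. Compound 3 is `FC(F)(F)Oc1ccc(Nc2cc(-c3cn[nH]c3)ncn2)cc1`; in this assay compound 3 also returns only the limit of > 10000 nM. Compound 2 thus stands nowhere distinct: its value is a limit, and the two further values shown are limits as well because of the limit of > 10000 nM in this assay, at which 3 of the 3 values shown sit.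

Compound 4 is `NC(=O)c1ccc(Cn2ncc3c(Nc4ccc(OC(F)(F)F)cc4)ncnc32)cc1`. It differs from compound 2 by 4-carbamoylphenyl in place of methyl on a saturated chain carbon bound to an aromatic nitrogen. Within the data shown here, no measured pair differing in one place exists in this set, so no size of step can be read from the data, and the three limits give no direction either. Among the measured compounds shown here, a change by the 4-carbamoylphenyl group on the saturated chain carbon bound to an aromatic nitrogen has no counterpart among the measured compounds. The expectation is therefore no step beyond the scatter, with compound 4 most likely again reported as a limit. The expected step is a step that the limit leaves unreadable from compound 2 to compound 4. For compound 4 the estimate in this assay is 15000 nM, ranging from 4000 nM to 60000 nM.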

Compound 4, half-maximal effective concentration: > 10000 nM
Compound 4: only a limit was reported (the forecaster's own chance of this, stated with the estimate: 80%); the middle value is on the limit's open side.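

In this assay compound 4 gives > 10000 nM, which is a limit. No step can be read between compound 2 and compound 4 because both are reported only as limits: the limit of > 10000 nM in this assay, at which 4 of the 4 values shown sit. The compounds shown leave open at what concentration any of them reaches the half-maximal effect, and whether 4-carbamoylbenzyl in place of ethyl changes it.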